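The source may report more compounds than this note shows. Statements on the series, on what has been measured and on what is new or still open speak of the compounds shown alone.

Measured so far:
- compound 1 `NS(=O)(=O)c1ccc(N2N=C(c3cccc(O)c3)C[C@H]2c2ccc(O)cc2)cc1` — 77.7%
- compound 2 `COc1cc([C@@H]2CC(c3cccc(O)c3)=NN2c2ccc(S(N)(=O)=O)cc2)cc(OC)c1OC` — 74.4%

Both compounds share a core and differ in the aryl group on the saturated ring carbon. In a functional assay on the whole organism (strain Wistar albino) for inhibition, with Rattus norvegicus as the target, read by paw edema, with stated times of 30 min and 5 h, at a dose of 0.05 mmol/kg (on this read-out higher numbers stand for more inhibition at the one dose given (going by the name of the read-out) and lower numbers for less inhibition), compound 1 gives 77.7% and compound 2 gives 74.4%; the two numbers lie within the scatter of each other, so neither can be ranked above the other. Compound 1 holds the higher of the two numbers, and nothing more than that can be read from the pair.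

Compound 3 `NS(=O)(=O)c1ccc(N2N=C(c3cccc(O)c3)C[C@H]2/C=C/c2ccccc2)cc1` has not been measured. It differs from compound 1 in one place: 2-phenylethenyl in place of 4-hydroxyphenyl on a saturated ring carbon. The aromatic ring is kept, the hydroxyl of the 4-hydroxyphenyl group is lost, and a double bond outside aromatic rings is introduced with the 2-phenylethenyl group. Within the data shown here, no measured pair covers a change of this kind, so there is no step to lean on.

The expectation for the step of a number 7.7 percentage points lower from compound 1 to compound 3 (within the scatter) is a small move, if any, toward less inhibition, not clearly beyond the scatter. Compound 3 is estimated at 70% in this assay, with a range from 55% to 82%.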

Compound 3, a percentage reported as inhibition, in the whole organism at one dose (the size of the read-out at that dose, not a potency): 59.2%
Compound 3: the middle estimate sits 10.8 percentage points above what was measured, within the range that was stated.
By their numbers in this assay, from the lowest: compound 3; then compounds 2 and 1 (each within the scatter of the next).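

In this assay, among these compounds, the saturated ring carbon of the shared core is not indifferent to its substituent: 2-phenylethenyl in place of 4-hydroxyphenyl gives a number 18.5 percentage points lower from compound 1 to compound 3 (beyond the scatter), the first step at this position that the numbers can resolve. The earlier pair showed no such thing, as compound 1 at 77.7% and compound 2 at 74.4% lie within the scatter of each other, so the aryl group of compound 2 on this carbon left no readable mark. The new step loses the hydroxyl and brings in a double bond outside aromatic rings together, and nothing available separates these two changes or accounts for the lower number.

Left open is which of the two changes carries the step: a saturated 2-phenylethyl group or a plain phenyl on this carbon would pull them apart. Also open, as far as these compounds go, is how the read-out responds when an amine or a carboxylic acid takes the place of the hydroxyl on the aromatic ring at this position.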